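This account rests on a few compounds, and the source may have more. Where it says the series, first, only, none or still open, it means among the compounds named here.

Three related compounds have been measured so far in a physicochemical assay for solubility, in phosphate buffer, at pH 7.4 (on this read-out lower numbers stand for lower solubility and higher numbers for higher solubility), and they set the frame for what follows. There compound 1 (`OCC1CCN(c2nccnc2OC2CN(c3nc4ccccc4s3)C2)CC1`) gives 31000 nM and compound 2 (`OCC1CCN(c2nccnc2OC2CN(c3ncc4ccccc4n3)C2)CC1`) gives 174000 nM while compound 3 (`COCC1CCN(c2nccnc2OC2CN(c3ccc4ccccc4n3)C2)CC1`) gives 53000 nM on the same read-out. Compound 3 thus lies within the scatter of compound 1 and beyond the scatter under compound 2.

The next compound, compound 4 (`OCc1cccc(-c2nccnc2OC2CN(c3ccc4ccccc4n3)C2)c1`), carries 3-(hydroxymethyl)phenyl in place of 4-(methoxymethyl)piperidin-1-yl on an aromatic carbon and this carbon sits next to the ring nitrogen. A six-membered non-aromatic ring with 1 hetero atom thereby gives way to a six-membered aromatic ring of carbon only.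

Among the measured compounds shown here, no two measured compounds differ in one place alone, so no measured step speaks directly to this change. The expectation rests instead on compound 3 at 53000 nM and on the span from compound 1 at 31000 nM to compound 2 at 174000 nM in these data. The expected step in this assay is small and downward, with an estimated 1.8-fold lower number from compound 3 to compound 4 (0.25 log units; within the scatter) as its likely size. For compound 4 the estimated value is 30000 nM with an expected range from 8000 nM to 100000 nM once it is measured.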

Compound 4, solubility: 29000 nM
For compound 4 the middle estimate is 1.0-fold (0.01 log units) above the measured one, and the stated range covers the measured number.
By their numbers in this assay, from the lowest: compounds 4, 1 and 3 (each within the scatter of the next); then compound 2.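

In this assay, among the compounds shown here, putting 3-(hydroxymethyl)phenyl in place of 4-(methoxymethyl)piperidin-1-yl on the aromatic carbon next to the ring nitrogen gives a 1.8-fold lower number from compound 3 to compound 4 (0.26 log units; within the scatter), the first measured step at this position. On this single pair, the read-out does not separate the two groups, even though one brings a six-membered non-aromatic ring with 1 hetero atom and the other a six-membered aromatic ring of carbon only, and their counts of hydrogen-bond donors and acceptors differ. No evidence is available on what lies behind the size of this step.

The compounds shown leave open whether the same step would read alike with the other end groups on the shared core, as compound 1 and compound 2 have no partner here that differs from them in one place alone. Also open, going by these compounds, is how an aminomethyl group or a carboxylic acid in place of the hydroxymethyl of 3-(hydroxymethyl)phenyl would stand in this assay, and how a plain phenyl would compare with both.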